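Changing the Ring-Nitrogen Group and Liver Microsome Stability

A few compounds are considered here, and "the series" means these few. Any claim that something is new, unique, unknown or untested is made for them only; others in the source may bear on it.

Compound 1 `CS(=O)(=O)N1CC2(CC(NC(=O)c3cc(-c4ccccc4)no3)C2)C1`: 76%
Compound 2 `CC(=O)N1CC2(CC(NC(=O)c3cc(-c4ccccc4)no3)C2)C1`: > 100%
Compound 3 `CCN1CC2(CC(NC(=O)c3cc(-c4ccccc4)no3)C2)C1`: 100%

In an ADME assay on microsomes from liver (Homo sapiens) for metabolic stability, with a stated time of 0.5 h, tested at 0.5 mg/mL (on this read-out lower numbers stand for a less stable compound and higher numbers for a more stable compound), compound 3 gives 100%, the highest of the two plain numbers, with compound 1 nearest; the step of a number 24 percentage points higher from compound 1 to compound 3 (beyond the scatter) is beyond the scatter. For compound 2 the value is a limit of the assay (the limit of > 100% in this assay, at which 1 of the 3 values shown sits), not a number. Compound 4 `CC(C)C(=O)N1CC2(CC(NC(=O)c3cc(-c4ccccc4)no3)C2)C1` differs from compound 3 in one place: isopropylcarbonyl in place of ethyl on an amine nitrogen in a ring. Within the data shown here, two measured steps bear on this position, a number at least 24 percentage points higher from compound 1 to compound 2 (beyond the scatter) and a number 24 percentage points higher from compound 1 to compound 3 (beyond the scatter), but both replace methylsulfonyl rather than ethyl. The closest comparison, a number no higher from compound 2 to compound 3 (the limit leaves the size open), leaves its size open. Compound 4 is therefore expected to show a step of a number 2 percentage points lower from compound 3 to compound 4 (within the scatter), within the scatter. The estimate for compound 4 is 98%, between 86% and 100%.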

Compound 4, percent of the compound remaining: 79%
Beside the measured number, compound 4's estimate is 19 percentage points above it; measured number outside the range, below it.
By their numbers in this assay, from the lowest: compounds 1 and 4 (each within the scatter of the next); then compound 3.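

In this assay, isopropylcarbonyl on the ring nitrogen does not keep the high stability seen with ethyl, a number 21 percentage points lower from compound 3 to compound 4 (beyond the scatter), and it reads level with methylsulfonyl, a number 3 percentage points higher from compound 1 to compound 4 (within the scatter). On the carbonyl carbon, isopropyl in place of methyl also gives a clear fall, a number at least 21 percentage points lower from compound 2 to compound 4 (beyond the scatter), so a carbonyl at this position does not by itself keep the number high. The value of compound 2 is a limit, not a number: the limit of > 100% in this assay, at which 1 of the 4 values shown sits.

Still open, as far as these compounds go, is how an ethyl or cyclopropyl group on that carbonyl carbon would behave. A longer chain directly on the ring nitrogen is also untested among the compounds shown.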